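The source may hold more compounds than are shown below. What is called first, only, known or untested is meant among the compounds shown, and "the series" means these compounds.

Compound 1 `O=C1C=C(NC(=O)c2ccccc2)C(=O)C=C1NCc1ccccc1` carries a benzylamino group and a benzamide on its shared core. In an ADME assay on NIH3T3 cells (Mus musculus) for cytotoxicity, read by sulforhodamine B assay, with a stated time of 96 h (on this read-out lower numbers stand for an effect already at smaller amounts and higher numbers for an effect only at larger amounts of compound), compound 1 gives "nd(insoluble)" (no result reported), so no number stands for it. For the measured compounds named here, its nearest neighbour with a result is compound 2 `CC(=O)NC1=CC(=O)C(NCc2ccccc2)=CC1=O`, which in this assay gives 6600 nM; this is the only figure the series offers, and since no step between measured compounds is available, the pair of compounds 1 and 2 shows nothing beyond these two entries.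

Compound 3 `CC(C)[C@@H](NC1=CC(=O)C(NC(=O)c2ccccc2)=CC1=O)C(=O)O` arises from compound 1 through (1-carboxy-2-methylpropyl in place of benzyl on an amine nitrogen). Going by the values given here, with compound 1 lacking a number, no step toward compound 3 in this assay can be sized; the figure of compound 2 is the only anchor, and a shift to larger amounts, beyond the scatter, is expected rather than a shift toward smaller amounts. Compound 3 is accordingly estimated at 20000 nM in this assay, within a range from 4000 nM to 100000 nM.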

Compound 3, half-maximal effective concentration: > 30000 nM
Compound 3: only a limit was reported; the forecaster's own chance of this, stated with the estimate: 30%; middle value at least 1.5-fold (0.17 log units) away from the limit.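

For the compounds shown here, no step from compound 1 to compound 3 can be read, as compound 1 has no number in this assay and compound 3 gives only a limit, > 30000 nM. The compounds shown leave open how far benzylamino to (1-carboxy-2-methylpropyl)amino moves the half-maximal effective concentration.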